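The source may report more compounds than this note shows. Statements on the series, on what has been measured and on what is new or still open speak of the compounds shown alone.

Compound 2 `CCN(CC)Cc1ccc2nc(NC(=O)N/N=C/c3c[nH]c4ccccc34)sc2c1` stands in a functional assay on NCI-H460 cells (Homo sapiens) for cytotoxicity, read by MTT assay, with a stated time of 72 h (a lower number here means a stronger inhibitor, a higher number a weaker inhibitor), at 3140 nM, the second highest of the three numbers in hand. Compound 3 `CC1CCN(Cc2ccc3nc(NC(=O)N/N=C/c4c[nH]c5ccccc45)sc3c2)CC1` gives 4130 nM, a step of a 1.3-fold higher number from compound 2 to compound 3 (0.12 log units; within the scatter) for 4-methylpiperidin-1-yl in place of diethylamino on a saturated chain carbon bound to an aromatic carbon. For the measured compounds named here, compound 1 `O=Cc1cn(Cc2ccc(Cl)cc2)c2ccccc12` gives 850 nM; no step between compound 1 and compound 2 is in hand, only the two values. Compound 4 `CCN(CC)Cc1ccc2nc(NC(=O)N/N=C/c3cn(Cc4ccc(Cl)cc4)c4ccccc34)sc2c1` differs from compound 2 by 4-chlorobenzyl in place of hydrogen on an aromatic nitrogen. Going by the values given here, no measured step concerns this aromatic nitrogen; the only measured step touches another part of the molecule and lies within the scatter. Compound 1 carries the same 4-chlorobenzyl group and gives 850 nM, which weakly points toward a lower number. Compound 4 is therefore expected to move a 1.6-fold lower number from compound 2 to compound 4 (0.20 log units; within the scatter). The estimate for compound 4 is 2000 nM, within 700 nM to 6000 nM.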

Compound 4, half-maximal inhibitory concentration: 370 nM
Compound 4: the middle estimate sits 5.4-fold (0.73 log units) above what was measured; measured number outside the range, below it.
By their numbers in this assay, from the lowest: compound 4; then compound 1; then compounds 2 and 3 (each within the scatter of the next).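

In this assay, for the compounds shown here, the aromatic nitrogen proves to be a sensitive position: 4-chlorobenzyl in place of hydrogen gives an 8.5-fold lower number from compound 2 to compound 4 (0.93 log units; beyond the scatter) and so moves the number beyond the scatter, which the only earlier step, at the 4-methylpiperidin-1-yl change, did not do. No measurement offered here explains this gain.

From the compounds shown here alone, whether a plain benzyl, a methyl or a benzyl bearing a carboxylic acid on this nitrogen would give a step of similar size remains open. Also open, going by these compounds, is whether 4-chlorobenzyl acts the same way on compound 3 with its 4-methylpiperidin-1-yl group.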